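Replacing the Methylsulfonyl Group in a Spirocyclic Carbamate Series

A few compounds are considered here, and "the series" means these few. Any claim that something is new, unique, unknown or untested is made for them only; others in the source may bear on it.

Compound 1, `CC(C)OC(=O)N1CCC2(CC1)CC(CCCOc1ccc(S(C)(=O)=O)cc1)C2`: 0.17 ug/mL
Compound 2, `CC(C)OC(=O)N1CCC2(CC1)CC(CCCOc1ccc(S(C)(=O)=O)c(F)c1)C2`: < 0.16 ug/mL (a limit)
Compound 3, `CCc1cnc(N2CCC3(CC2)CC(CCCOc2ccc(S(C)(=O)=O)cc2)C3)nc1`: < 0.12 ug/mL (a limit)

In a physicochemical assay for solubility, read by HPLC, in phosphate buffer, with a stated time of 24 h, at pH 6.8 (on this read-out lower numbers stand for lower solubility and higher numbers for higher solubility), compound 1 gives 0.17 ug/mL. For compound 2 this assay reports only a limit, < 0.16 ug/mL. For compound 3 this assay likewise reports only a limit, < 0.12 ug/mL. Compound 2 therefore stands at a limit, and one of the two other values shown is a limit as well. The measured steps are an at least 1.0-fold lower number from compound 1 to compound 2 (0.02 log units; that floor lies within the scatter) and an at least 1.4-fold lower number from compound 1 to compound 3 (0.15 log units; that floor lies within the scatter); each is only a floor, and each floor lies within the scatter. Compound 4, `CC(C)OC(=O)N1CCC2(CC1)CC(CCCOc1ccc(C(=O)N3CC(O)C3)c(F)c1)C2`, differs from compound 2 by (3-hydroxyazetidin-1-yl)carbonyl in place of methylsulfonyl on an aromatic carbon. Neither measured step touches that group, so they give no direction for this change beyond the scatter. Compound 4 is expected to give 1 ug/mL, with a range from 0.15 ug/mL to 8 ug/mL. That expectation corresponds to an estimated step of an at least 6.2-fold higher number from compound 2 to compound 4 (0.79 log units; beyond the scatter).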

Compound 4, solubility: 1.89 ug/mL
Estimate against measurement, compound 4: 1.9-fold (0.28 log units) below; the range from low to high includes it.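

In this assay, (3-hydroxyazetidin-1-yl)carbonyl in place of methylsulfonyl, ortho to a fluoro group, gives an at least 11-fold higher number from compound 2 to compound 4 (1.07 log units; beyond the scatter). The earlier steps, at the fluoro group and the amine nitrogen, showed only floors within the scatter, so this is the first change shown to move the number beyond it. That size is itself a floor, since compound 2 stands at a limit: the limit of < 0.16 ug/mL in this assay, at which 1 of the 4 values shown sits.

From the compounds shown here alone, whether a plain carboxylic acid or an open-chain amide at this position would do the same remains open. So does whether the replacement carries over to the 5-ethylpyrimidin-2-yl compound 3.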